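Phenyl for chloropyridinyl on a weakly cytotoxic amide

The compounds below may be only part of what the source reports. "The series", "measured", "known", "first", "only" and "open" are said of these compounds alone.

The series is judged in a functional assay on NALM-6 cells (Homo sapiens) for cytotoxicity, read by MTT assay, with a stated time of 48 h; on this read-out higher numbers stand for weaker inhibition and lower numbers for stronger inhibition. Compound 1 `O=C(Nc1cc(C(F)(F)F)ccc1N1CCCC1)c1ccncc1` is reported as "not active" (no number reported), without a number. Compound 2 `O=C(Nc1cc(C(F)(F)F)ccc1Nc1ccc(Br)cc1)c1cccnc1Cl` gives 35700 nM, the lower of the two numbers in hand, and compound 3 `CCN(CC)c1ccc(C(F)(F)F)cc1NC(=O)c1cccnc1` gives 63200 nM, a value that lies within the scatter of compound 2, so no order can be drawn between them. Compound 4 `O=C(Nc1cc(C(F)(F)F)ccc1Nc1ccc(Br)cc1)c1ccccc1` has not yet been measured. Its change from compound 2 is phenyl in place of 2-chloropyridin-3-yl on a carbonyl carbon. Among the measured compounds shown here, no measured pair shows the effect of such a change, so only the weak activity of the set guides the expectation. Compound 4 is expected to give 50000 nM, between 15000 nM and 150000 nM. The expected step of a 1.4-fold higher number from compound 2 to compound 4 (0.15 log units; within the scatter) is no change beyond the scatter.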

Compound 4, half-maximal inhibitory concentration: 6000 nM
Compound 4: middle estimate off by 8.3-fold (0.92 log units), on the high side; the measured number lies below the stated range.
By their numbers in this assay, from the lowest: compound 4; then compounds 2 and 3 (each within the scatter of the next).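

In this assay, among the compounds shown here, phenyl in place of 2-chloropyridin-3-yl on a carbonyl carbon gives a 6.0-fold lower number from compound 2 to compound 4 (0.77 log units; beyond the scatter) and so shows that the group at this position can change the read-out, which the earlier compounds could not show. The change removes the ring nitrogen and the chlorine together, so the step cannot be assigned to either one alone. No evidence at hand explains the step.

Going by these compounds, whether a chlorophenyl or a methoxyphenyl group at this position would give a similar number remains open.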